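The compounds below may be only part of what the source reports. "The series", "measured", "known", "first", "only" and "open" are said of these compounds alone.

Among the compounds with values here, compound 1 `CN1CCN(CC(=O)Nc2ccc(-c3nc4cc(Cl)c(Cl)cc4[nH]3)cc2)CC1` is the only compound in this set with a number in an ADME assay on MDBK cells (Bos taurus) for cytotoxicity, read by MTT assay, with a stated time of 96 h; on this read-out higher numbers stand for lower toxicity in this test and lower numbers for higher toxicity in this test; the one other value is a limit. In this assay compound 1 gives 90000 nM. Compound 2 `COc1ccc(-c2nc3cc([N+](=O)[O-])ccc3[nH]2)c(OC)c1OC` reaches only a limit of the assay: in this assay compound 2 gives > 100000 nM, which is a limit and not a number. Where compound 1 stands can be set against (the limit of > 100000 nM in this assay, at which 1 of the 2 values shown sits).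

Compound 3 `O=C(CN1CCCCC1)Nc1ccc(-c2nc3cc(Cl)c(Cl)cc3[nH]2)cc1` has not yet been measured in this assay. It differs from compound 1 in one place: piperidin-1-yl in place of 4-methylpiperazin-1-yl on a saturated chain carbon bound to a carbonyl carbon. Within the data shown here, no step between two measured compounds exists here, so nothing in these data shows how such a change moves the read-out. For compound 3 the expected step is a 1.3-fold lower number from compound 1 to compound 3 (0.11 log units; within the scatter), a shift no larger than the usual scatter. Compound 3 is therefore estimated at 70000 nM, with a range from 25000 nM to 200000 nM.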

Compound 3, half-maximal cytotoxic concentration: 45000 nM
For compound 3 the middle estimate is 1.6-fold (0.19 log units) above the measured one, and the stated range covers the measured number.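

In this assay the place on a saturated chain carbon bound to a carbonyl carbon now has its first readable change, piperidin-1-yl in place of 4-methylpiperazin-1-yl (a 2.0-fold lower number from compound 1 to compound 3 (0.30 log units; within the scatter)). Exchanging the six-membered ring with 2 hetero atoms for the one with 1 hetero atom thus leaves compound 3 and compound 1 within the usual scatter of each other, so this single pair shows that the read-out tolerates this exchange on the shared core. Nothing shown here offers a reason for this result.

The compounds shown leave open how a morpholine ring, an open-chain dimethylamino group or a carboxylic acid would read at this place. They also leave open whether a longer chain between the carbonyl and the ring would give a number outside the scatter.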